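Ethoxymethyl to isopropoxymethyl on the shared core

A few compounds are considered here, and "the series" means these few. Any claim that something is new, unique, unknown or untested is made for them only; others in the source may bear on it.

Measured so far in a functional assay on MES-SA/Dx5 cells (Homo sapiens) for inhibition, with a stated time of 72 h; a higher number here means a weaker inhibitor, a lower number a stronger inhibitor:
compound 1 `CC1CCN(Cc2cc(Cl)c3cccnc3c2O)CC1` gives 260 nM; 257 nM (2 entries)
compound 2 `CCOCc1cc(CN2CCC(C)CC2)c(O)c2ncccc12` gives 468 nM

The repeat entries of compound 1 agree closely (the several entries of compound 1 in this assay, 260 nM; 257 nM (2 entries)). Within the data shown here, for compound 2, 468 nM is the only number available, and a further entry gives no single number, so its position rests on one reading. The values of compound 1 and compound 2 lie within the usual scatter of each other.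

Compound 3 `CC1CCN(Cc2cc(COC(C)C)c3cccnc3c2O)CC1` is the next to consider. Its change from compound 2 is ethoxy to isopropoxy, with methyl in place of hydrogen on a saturated chain carbon bound to an oxygen on a saturated carbon and a saturated chain carbon. Among the measured compounds shown here, no measured step isolates this change, so the expectation rests on the single reading of compound 2 at 468 nM and on the small size of the change. The expected step of a 1.0-fold lower number from compound 2 to compound 3 (0.02 log units; within the scatter) is small, has no firm direction and does not go beyond the scatter. In this assay the estimate for compound 3 is 450 nM as a middle value, with 220 nM to 900 nM as the expected range.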

Compound 3, half-maximal inhibitory concentration: 355 nM
The estimate for compound 3 lay 1.3-fold (0.10 log units) above the measured number; measured number inside the range.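

In this assay, among these compounds, ethoxy to isopropoxy on the shared core gives a 1.3-fold lower number from compound 2 to compound 3 (0.12 log units; within the scatter), the first measured step to isolate methyl in place of hydrogen on a saturated chain carbon bound to an oxygen on a saturated carbon and a saturated chain carbon. At this position, the change from ethoxymethyl to isopropoxymethyl therefore leaves no readable effect on the number, and compound 2 and compound 3 count as equal in this assay, although each rests on one numerical reading. The only direct check on repeat agreement comes from compound 1, which carries no information on the step itself but shows how closely two entries can agree in this assay: the several entries of compound 1 in this assay, 260 nM; 257 nM (2 entries)

From the compounds shown here alone, whether this position stays equally flat with a larger or different group, such as a longer chain like butoxymethyl, an amine or a carboxylic acid, remains open. Going by these compounds, it also remains open whether the step from ethoxy to isopropoxy would stay within the scatter on other cells or at another exposure time.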